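The compounds below may be only part of what the source reports. "The series", "measured", "known", "first", "only" and "open" are said of these compounds alone.

Measured compounds in an assay on microsomes from brain for inhibition of Fatty-acid amide hydrolase 1 (Rattus norvegicus), read by fluorescence and HPLC, with a stated time of 60 min; a higher number here means a weaker inhibitor, a lower number a stronger inhibitor:
- compound 1 `CCCCCCCCc1ccc(OCC(=O)Cn2nnnc2SC)cc1` gives 22 nM
- compound 2 `CCCCCCCCc1ccc(OCC(=O)Cn2nnnc2-c2ccccc2)cc1` gives 71 nM
- compound 3 `CCCCCCCCc1ccc(OCC(=O)Cn2nnnc2-c2cccs2)cc1` gives 55 nM

Compound 3 stands second highest of the three numbers in this assay; compound 2 is nearest to it, and compound 1 is furthest, with a lower number. The step of a 2.5-fold higher number from compound 1 to compound 3 (0.40 log units; beyond the scatter) and the step of a 3.2-fold higher number from compound 1 to compound 2 (0.51 log units; beyond the scatter) both run in the same direction, while the step of a 1.3-fold lower number from compound 2 to compound 3 (0.11 log units; within the scatter) is small.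

Compound 4 `CCCCCCCCc1ccc(OCC(=O)Cn2nnnc2-c2cccc(C(=O)O)c2)cc1` differs from compound 3 as follows: 3-carboxyphenyl in place of thiophen-2-yl on an aromatic carbon. The two aryl replacements seen so far, from compound 1 to compound 2 and from compound 1 to compound 3, each gave a modest rise in the number, and the exchange of one aryl group for another between compound 2 and compound 3 gave no step beyond the scatter. Within the data shown here, no measured compound carries a carboxylic acid, so that part of the change is uncharted. On this basis the step of a 1.8-fold higher number from compound 3 to compound 4 (0.26 log units; within the scatter) is expected to be modest, and the number for compound 4 in this assay is estimated at 100 nM, within a range of 30 nM to 400 nM.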

Compound 4, half-maximal inhibitory concentration: 1800 nM
Compound 4: the middle estimate sits 18-fold (1.26 log units) below what was measured, outside the stated range (above it).
By their numbers in this assay, from the lowest: compound 1; then compounds 3 and 2 (each within the scatter of the next); then compound 4.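

In this assay, replacing one aryl group with another at this position on the shared core had given no step beyond the scatter, and neither aryl group had moved far from methylsulfanyl. Adding only a carboxy group to the phenyl of compound 2 now gives a 25-fold higher number from compound 2 to compound 4 (1.40 log units; beyond the scatter) and shows that this single group on the aryl ring changes the result far more than the choice of ring did. The exchange for thiophen-2-yl gives a 33-fold higher number from compound 3 to compound 4 (1.51 log units; beyond the scatter) and the exchange for methylsulfanyl gives an 82-fold higher number from compound 1 to compound 4 (1.91 log units; beyond the scatter) as large steps, but nothing available explains the size of this effect.

From the compounds shown here alone, it remains open whether a methyl ester or a primary amide in place of the carboxylic acid would give a step of similar size. Going by these compounds, it is also open whether a carboxylic acid on the thiophen-2-yl ring or at the end of a longer chain would do so.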